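The source may hold more compounds than are shown below. What is called first, only, known or untested is meant among the compounds shown, and "the series" means these compounds.

Among the measured compounds shown here, compound 3 `COc1cc(N)c(Cl)cc1NC(=O)C1CCN(Cc2ccccc2)CC1` gives 0.5 mg/kg in a functional assay on the whole organism for antagonist activity, with Mus musculus as the target (a higher number here means that more compound is needed for the effect, a lower number that less compound is needed), one of only two numbers. Compound 1 `COc1cc(N)c(Cl)cc1NC(=O)C1CCN(Cc2ccc(F)cc2)CC1` gives 0.6 mg/kg in this assay, and the step of a 1.2-fold lower number from compound 1 to compound 3 (0.08 log units; within the scatter) sits within the scatter. Compound 2 `COc1cc(N)c(Cl)cc1NC(=O)C1CCN(CC2CCCCCC2)CC1` reaches only a limit of this assay, > 10 mg/kg. The steps of an at least 16-fold higher number from compound 1 to compound 2 (1.22 log units; beyond the scatter) and an at least 20-fold lower number from compound 2 to compound 3 (1.30 log units; beyond the scatter) are large, both resting on (the limit of > 10 mg/kg in this assay, at which 1 of the 3 values shown sits). Compound 4 `COc1cc(N)c(Cl)cc1NC(=O)C1CCN(Cc2ccsc2)CC1` differs from compound 3 by thiophen-3-yl in place of phenyl on a saturated chain carbon bound to an amine nitrogen in a ring. An aromatic ring stays on the saturated chain carbon bound to an amine nitrogen in a ring, so the change resembles the small aryl step rather than the cycloheptyl steps; no step beyond the scatter is expected in this assay. Compound 4 is estimated at 0.6 mg/kg, within 0.25 mg/kg to 1.5 mg/kg, the expected step being a 1.2-fold higher number from compound 3 to compound 4 (0.08 log units; within the scatter).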

Compound 4, dose for half-maximal effect: 3.4 mg/kg
Compound 4: the middle estimate sits 5.7-fold (0.75 log units) below what was measured; the measured number lies above the stated range.
By their numbers in this assay, from the lowest: compounds 3 and 1 (each within the scatter of the next); then compound 4. At a limit, above all of these: compound 2.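

In this assay, an aromatic ring at this position does not by itself keep the number low: a 6.8-fold higher number from compound 3 to compound 4 (0.83 log units; beyond the scatter) and a 5.7-fold higher number from compound 1 to compound 4 (0.75 log units; beyond the scatter) are both modest and beyond the scatter, unlike the hydrogen-for-fluoro change on the phenyl ring. Compound 4 still gives the lower number against cycloheptyl in an at least 2.9-fold lower number from compound 2 to compound 4 (0.46 log units; beyond the scatter), but that step rests on a limit: the limit of > 10 mg/kg in this assay, at which 1 of the 4 values shown sits.

Whether the sulfur or the five-membered ring goes with the higher number stays open, since thiophen-3-yl is the only five-membered ring shown. Thiophen-2-yl, furan-3-yl and pyridin-3-yl on the same carbon would bear on that question.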